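Isopropyl to isobutyl on the ester oxygen

A few compounds are considered here, and "the series" means these few. Any claim that something is new, unique, unknown or untested is made for them only; others in the source may bear on it.

Going by the values given here, in a functional assay on the whole organism for inhibition, with Scenedesmus acutus as the target (on this read-out higher numbers stand for weaker inhibition and lower numbers for stronger inhibition), compound 1 `O=C(O)c1cc(N2C(=O)C3=C(CCCC3)C2=O)c(F)cc1Cl` gives 1000 nM, while compound 2 `CC(C)OC(=O)c1cc(N2C(=O)C3=C(CCCC3)C2=O)c(F)cc1Cl` gives 13.8 nM, the lowest of the two numbers so far. The next structure is compound 3 `CC(C)COC(=O)c1cc(N2C(=O)C3=C(CCCC3)C2=O)c(F)cc1Cl`, with isobutyl in place of isopropyl on an oxygen next to a carbonyl group. Among the compounds with values here, one measured step bears on this change: isopropyl in place of hydrogen on that same oxygen, a 72-fold lower number from compound 1 to compound 2 (1.86 log units; beyond the scatter), a large step beyond the scatter. Within the data shown here, that step starts from hydrogen, and no measured pair yet compares two carbon chains at this oxygen, so its size does not carry over. Only a small step is expected here, towards a slightly higher number and within the scatter: a 1.4-fold higher number from compound 2 to compound 3 (0.16 log units; within the scatter). In this assay the expected value for compound 3 is 20 nM, with an estimated range from 7 nM to 55 nM.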

Compound 3, half-maximal inhibitory concentration: 100 nM
Estimate against measurement, compound 3: 5.0-fold (0.70 log units) below; measured number above the stated range.
By their numbers in this assay, from the lowest: compound 2; then compound 3; then compound 1.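

Comparing two carbon chains on this oxygen shows that the choice of ester chain matters in its own right: in this assay, isobutyl in place of isopropyl gives a 7.2-fold higher number from compound 2 to compound 3 (0.86 log units; beyond the scatter), so a single added carbon separates these two esters. The isobutyl ester still differs clearly from the carboxylic acid, with a 10-fold lower number from compound 1 to compound 3 (1.00 log units; beyond the scatter), so this gain is smaller than the one seen with isopropyl. Nothing measured here explains the difference between the two chains.

On these data alone, with only isopropyl and isobutyl compared, it remains open whether the step follows branching or chain length, and an ethyl, a straight-chain butyl or a cyclopentyl ester would help separate these readings. As far as these compounds go, whether an amide could take the place of the ester on the shared core also remains open.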